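The source may hold more compounds than are shown below. What is called first, only, known or untested is meant among the compounds shown, and "the series" means these compounds.

Working notes on the series. Of the compounds shown here, two of the shared core have been measured in an assay on isolated protein for inhibition of tyrosine-protein kinase receptor UFO (Homo sapiens), read by FRET and Z'-LYTE, with a stated time of 1.5 h; a higher number here means a weaker inhibitor, a lower number a stronger inhibitor. Compound 1 `Cc1ccc2c(c1)c(=O)c(C(=O)Nc1ccc(Oc3ncnc4[nH]cc(-c5ccccc5)c34)c(F)c1)c(C)n2C` gives 100 nM in this assay. Compound 2 `Cc1ccc2c(c1)c(=O)c(C(=O)Nc1ccc(Oc3ncnc4[nH]cc(-c5ccccc5)c34)c(F)c1)cn2C` gives 150 nM in this assay. Compound 2 stands with the highest number of the two, and its nearest neighbour is compound 1; the step of a 1.5-fold higher number from compound 1 to compound 2 (0.18 log units; within the scatter) is within the scatter, so no order between the two compounds is claimed.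

Compound 3 `CCc1c(C(=O)Nc2ccc(Oc3ncnc4[nH]cc(-c5ccccc5)c34)c(F)c2)c(=O)c2cc(C)ccc2n1C` has not been measured. It differs from compound 2 by ethyl in place of hydrogen on an aromatic carbon. For the measured compounds named here, the only measured step that touches that carbon is a 1.5-fold higher number from compound 1 to compound 2 (0.18 log units; within the scatter), which replaced a methyl there with hydrogen and stayed within the scatter. Nothing in the measured set covers a chain of two carbons at that carbon. The step of a 1.4-fold lower number from compound 2 to compound 3 (0.13 log units; within the scatter) is therefore expected to be small, leaning if anything toward a lower number, and not beyond the scatter. Compound 3 is estimated at 110 nM in this assay, with a range from 50 nM to 250 nM.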

Compound 3, half-maximal inhibitory concentration: 78 nM
Estimate against measurement, compound 3: 1.4-fold (0.15 log units) above; the measured number falls inside the stated range.
By their numbers in this assay, from the lowest: compounds 3, 1 and 2 (each within the scatter of the next).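

Working notes, continued. In this assay the aromatic carbon next to the ring nitrogen has now carried hydrogen, methyl and ethyl, and both new steps, a 1.9-fold lower number from compound 2 to compound 3 (0.28 log units; within the scatter) and a 1.3-fold lower number from compound 1 to compound 3 (0.11 log units; within the scatter), lie within the scatter. For the compounds shown here, the earlier pair covered only hydrogen and methyl at this carbon, whereas these steps show that a chain of two carbons also leaves the number within the scatter of both smaller substituents, so the three compounds cannot be put in any order and the series so far shows no response to the size of this group. Nothing available bears on why this carbon shows so little response to the change.

As far as these compounds go, what a longer chain such as propyl, a branched group such as isopropyl, a phenyl ring, an amine or a carboxylic acid would do at this carbon stays open, so the point at which a group here would move the number beyond the scatter is unknown. The reading also rests on a single core and a single assay, leaving open whether the same substitutions would behave alike with other groups elsewhere on the core.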